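Phenoxymethyl in place of 4-methylphenyl: working notes

The source may report more compounds than this note shows. Statements on the series, on what has been measured and on what is new or still open speak of the compounds shown alone.

Values so far from a functional assay on HeLa cells (Homo sapiens) for cytotoxicity, read by MTT assay, with a stated time of 72 h (on this read-out lower numbers stand for stronger inhibition and higher numbers for weaker inhibition), are these
- compound 1 `O=C(COc1ccccc1)Nc1nnc(-c2cccc(O)c2O)s1` gives 117000 nM
- compound 2 `Cc1ccc(C(=O)Nc2nnc(-c3ccc(O)c(O)c3)s2)cc1` gives 67100 nM

In this assay compound 2 stands at 67100 nM and its only measured comparator, compound 1, at 117000 nM, so the two lie within the scatter of each other. Among the measured compounds shown here, no step between measured compounds that differ in one place is available, which leaves the next expectation thinly supported.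

Compound 3 `O=C(COc1ccccc1)Nc1nnc(-c2ccc(O)c(O)c2)s1` is the next to be read. It carries phenoxymethyl in place of 4-methylphenyl on a carbonyl carbon. Compound 1 also carries phenoxymethyl there, but its core differs from that of compound 3, so it offers only indirect guidance. With compound 1 at 117000 nM, no change beyond the scatter is expected from this swap. The expected size of the move is a 1.3-fold higher number from compound 2 to compound 3 (0.10 log units; within the scatter), a small shift toward a higher number that is estimated to stay within the scatter. Compound 3 is estimated at 85000 nM (expected range 35000 nM to 200000 nM).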

Compound 3, half-maximal inhibitory concentration: 51300 nM
The estimate for compound 3 lay 1.7-fold (0.22 log units) above the measured number; the range from low to high includes it.
By their numbers in this assay, from the lowest: compounds 3, 2 and 1 (each within the scatter of the next, the first and the last beyond it).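

In this assay, among the compounds shown here, the first step that changes only the group on the carbonyl carbon, phenoxymethyl in place of 4-methylphenyl, is a 1.3-fold lower number from compound 2 to compound 3 (0.12 log units; within the scatter), so with the 3,4-dihydroxyphenyl group held constant the two groups cannot be told apart at this position. For the compounds shown here, the change at the other end of the molecule, 3,4-dihydroxyphenyl in place of 2,3-dihydroxyphenyl on an aromatic carbon with phenoxymethyl held constant, is a 2.3-fold lower number from compound 1 to compound 3 (0.36 log units; beyond the scatter), a modest step and the only single-place step so far that clears the scatter, which suggests that the arrangement of the two hydroxyl groups registers more clearly in this read-out than the swap on the carbonyl carbon. Nothing on hand explains either step.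

On these data alone, it remains open whether the hydroxyl step keeps its direction and size when 4-methylphenyl, rather than phenoxymethyl, sits on the carbonyl carbon. As far as these compounds go, it is equally open whether the carbonyl position stays this flat with a group of a different kind there, such as an aliphatic amine, a carboxylic acid or a longer alkyl chain in place of the aromatic groups seen so far.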